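Trifluoromethyl in place of neopentyloxy on a carbonyl carbon

The source may report more compounds than this note shows. Statements on the series, on what has been measured and on what is new or still open speak of the compounds shown alone.

Compound 1 `COc1cc2ncnc(-n3nc(-c4ccccn4)nc3N)c2cc1OCCCN(C)C`: 53000 nM
Compound 2 `COCCOc1cc2c(-n3nc(-c4ccccn4)nc3N)ncnc2cc1OC`: 8000 nM
Compound 3 `COc1cc2ncnc(-n3nc(-c4ccccn4)nc3N)c2cc1OCCCNC(=O)OCC(C)(C)C`: 200 nM

In a physicochemical assay for solubility, in phosphate buffer, with a stated time of 18 h, at pH 7.4 (a lower number here means a less soluble compound, a higher number a more soluble compound), compound 3 has the lowest number of the three, at 200 nM. Compound 4 `COc1cc2ncnc(-n3nc(-c4ccccn4)nc3N)c2cc1OCCCNC(=O)C(F)(F)F` differs from compound 3 in one place: trifluoromethyl in place of neopentyloxy on a carbonyl carbon. In words, trifluoromethyl stands in place of neopentyloxy on a carbonyl carbon.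

Among the compounds with values here, no measured step makes this exact change, so the evidence is indirect. Two large steps bring in the (neopentyloxycarbonyl)amino group: a 270-fold lower number from compound 1 to compound 3 (2.42 log units; beyond the scatter), and a 40-fold lower number from compound 2 to compound 3 (1.60 log units; beyond the scatter). The remaining step, a 6.6-fold lower number from compound 1 to compound 2 (0.82 log units; beyond the scatter), is modest and does not involve that group. With the neopentyloxy part gone, a higher number in this assay is expected, though probably one that recovers only part of those large drops. The expected change is a 13-fold higher number from compound 3 to compound 4 (1.10 log units; beyond the scatter). For compound 4 the estimated value is 2500 nM, with an expected range of 600 nM to 10000 nM.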

Compound 4, solubility: 1000 nM
Compound 4: the middle estimate sits 2.5-fold (0.40 log units) above what was measured; the measured number falls inside the stated range.
By their numbers in this assay, from the lowest: compound 3; then compound 4; then compound 2; then compound 1.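

In this assay, within the data shown here, the swap of neopentyloxy for trifluoromethyl on a carbonyl carbon gives a 5.0-fold higher number from compound 3 to compound 4 (0.70 log units; beyond the scatter) as a modest step, the first reading of a change made on that carbonyl itself, and it shows that the number moves with the end of the group while the carbonyl and its amide-type nitrogen stay in place. The recovery remains partial, as the chain ending in ((trifluoromethyl)carbonyl)amino still sits well under the two other chain ends, with an 8.0-fold lower number from compound 2 to compound 4 (0.90 log units; beyond the scatter) against methoxy and a 53-fold lower number from compound 1 to compound 4 (1.72 log units; beyond the scatter) against dimethylamino as the larger of these gaps. Nothing measured here accounts for the size of these steps.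

The compounds shown leave open how a plain methyl on the same carbonyl carbon would read, which would separate the loss of neopentyloxy from the arrival of the fluorines. They also leave open where a free primary amine at the end of the same chain would fall.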